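A few compounds are considered here, and "the series" means these few. Any claim that something is new, unique, unknown or untested is made for them only; others in the source may bear on it.

Of the compounds shown here, three sharing one core have been tested in an ADME assay on HEK293 cells (Homo sapiens) for cytotoxicity, with a stated time of 72 h; a higher number here means that more compound is needed for the effect, a lower number that less compound is needed. Compound 1 `Cc1cc(NC(=O)Nc2ccc(C(C)(C)C)cc2)c2ccccc2n1` carries a tert-butyl group; in this assay compound 1 gives > 25000 nM, which is a limit of the assay and not a number. Compound 2 `Cc1cc(NC(=O)Nc2ccc(N(C)C)cc2)c2ccccc2n1` carries a dimethylamino group in the same position; in this assay compound 2 gives > 25000 nM, again a limit rather than a number. Compound 3 `Cc1cc(NC(=O)Nc2ccc(F)cc2F)c2ccccc2n1` is the only one of the three with a number: in this assay compound 3 gives 10000 nM.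

For the measured compounds named here, compound 2 therefore stands at the limit (the limit of > 25000 nM in this assay, at which 2 of the 3 values shown sit), and the single measured step that the two limits leave unreadable from compound 1 to compound 2 cannot be read in size or direction, since both ends are limits.

The compound still to be measured is compound 4 `Cc1cc(NC(=O)Nc2ccc(Cl)cc2)c2ccccc2n1`. Relative to compound 2 it differs as follows: chloro in place of dimethylamino on an aromatic carbon. No measured step concerns a chloro group, and the one step shown, from a tert-butyl to a dimethylamino group, is unreadable, so nothing observed points in either direction. Compound 3 shows that a halogen-bearing partner can reach a number rather than a limit. The expected result for compound 4 is 20000 nM, with a range from 8000 nM to 50000 nM, which would mean an estimated step of an at least 1.2-fold lower number from compound 2 to compound 4 (0.09 log units; that floor lies within the scatter).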

Compound 4, half-maximal effective concentration: > 25000 nM
Compound 4 was reported as a limit; the forecaster's own chance of this, stated with the estimate: 50%; middle value at least 1.2-fold (0.09 log units) from the limit.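

In this assay compound 4 gives > 25000 nM, which is a limit of the assay and not a number. The steps among compound 1, compound 2 and compound 4 therefore cannot be read, as both ends of each are limits: the limit of > 25000 nM in this assay, at which 3 of the 4 values shown sit.

The compounds shown leave open whether compound 1, compound 2 and compound 4 differ at all in this assay.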